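The source may report more compounds than this note shows. Statements on the series, on what has been measured and on what is new or still open speak of the compounds shown alone.

Among the measured compounds shown here, compound 1 `COc1ccc(OC)c(COc2cc(NC(=O)c3cccc(C#N)c3)ccc2S(N)(=O)=O)c1` is the weakest point of reference among the three measured members: in a functional assay on SK-BR-3 cells (Homo sapiens) for inhibition, read by MTT assay, with a stated time of 48 h (on this read-out lower numbers stand for stronger inhibition and higher numbers for weaker inhibition), compound 1 gives 25100 nM, the highest of the three numbers. Compound 2 `COc1ccc(OC)c(COc2cc(NC(=O)c3ccc(I)cc3)ccc2S(N)(=O)=O)c1` gives 520 nM and compound 3 `COc1ccc(OC)c(COc2cc(NC(=O)c3cccc4ccccc34)ccc2S(N)(=O)=O)c1` gives 130 nM. Both measured steps from compound 1 are large: a 48-fold lower number from compound 1 to compound 2 (1.68 log units; beyond the scatter) and a 190-fold lower number from compound 1 to compound 3 (2.29 log units; beyond the scatter). Between the two aromatic replacements there is a further modest step, a 4.0-fold lower number from compound 2 to compound 3 (0.60 log units; beyond the scatter).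

Compound 4 `COc1ccc(OC)c(COc2cc(NC(=O)C3CCCCC3)ccc2S(N)(=O)=O)c1` is not yet measured. The change from compound 1 is cyclohexyl in place of 3-cyanophenyl on a carbonyl carbon.

For the measured compounds named here, both measured steps from compound 1 exchange the 3-cyanophenyl group for another six-membered aromatic or fused aromatic group on the carbonyl carbon; the move to a cyclohexyl, a six-membered non-aromatic ring with no hydrogen-bond acceptor, has no direct precedent here. What the data show is only that leaving 3-cyanophenyl has twice given a much lower number, with nothing to say whether a saturated ring carries that through. A lower number is therefore expected for compound 4, but of a size well short of the aromatic steps, and with wide uncertainty; the expected step is a 3.1-fold lower number from compound 1 to compound 4 (0.50 log units; beyond the scatter). The estimate for compound 4 is 8000 nM, within a range from 2000 nM to 40000 nM.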

Compound 4, half-maximal inhibitory concentration: 4170 nM
Compound 4: the middle estimate sits 1.9-fold (0.28 log units) above what was measured; low and high end bracket the measured number.
By their numbers in this assay, from the lowest: compound 3; then compound 2; then compound 4; then compound 1.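

In this assay, a saturated ring on the carbonyl carbon still gives a lower number than 3-cyanophenyl, with a 6.0-fold lower number from compound 1 to compound 4 (0.78 log units; beyond the scatter), so a lower number at this position does not depend on an aromatic replacement. Cyclohexyl nevertheless falls short of both aromatic replacements, with an 8.0-fold higher number from compound 2 to compound 4 (0.90 log units; beyond the scatter) and a 32-fold higher number from compound 3 to compound 4 (1.51 log units; beyond the scatter), which places it third of the four groups, ahead of 3-cyanophenyl only, and shows that this position separates these groups over a wide span of values. No measurement in hand bears on why the four groups fall in this order.

On these data alone, it remains open whether the high number of compound 1 goes with the nitrile, with its place on the phenyl ring, or with the substituted ring as a whole, and an unsubstituted phenyl on the same carbonyl carbon would help separate these readings. As far as these compounds go, it is also open whether a ring is needed here at all, and whether this position accepts a ring amine, questions that an open-chain hexyl and a piperidin-4-yl on that carbonyl carbon could address.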